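This account rests on a few compounds, and the source may have more. Where it says the series, first, only, none or still open, it means among the compounds named here.

Measured in a functional assay on HepG2 cells (Homo sapiens) for cytotoxicity, read by MTT assay, with a stated time of 72 h; on this read-out higher numbers stand for weaker inhibition and lower numbers for stronger inhibition:
- Compound 1 `Nc1ccccc1NC(=O)c1ccc(Cn2cc(-c3ccc(NC(=O)NCc4cccnc4)cc3)nn2)cc1`: 8100 nM
- Compound 2 `Nc1ccccc1NC(=O)c1ccc(NC(=O)NCc2cccnc2)cc1`: 5100 nM
- Compound 3 `Nc1ccccc1NC(=O)c1ccc(NC(=O)NCc2ccc(Cl)nc2)cc1`: 2400 nM

Compound 3 has the lowest number of the three, and both other compounds lie beyond the scatter from it. Compound 4 `Nc1ccccc1NC(=O)c1ccc(NC(=O)NCc2ccc(F)nc2)cc1` differs from compound 3 in one place: fluoro in place of chloro on an aromatic carbon. Going by the values given here, one measured step bears on this, the swap of hydrogen for chloro on that ring: a 2.1-fold lower number from compound 2 to compound 3 (0.33 log units; beyond the scatter). Among the compounds with values here, no fluoro compound has been measured, so this is a weak guide. Fluoro is expected to give back part of that modest gain in this assay, with no change larger than that step. The expected change is small and may stay within the scatter: a 1.5-fold higher number from compound 3 to compound 4 (0.16 log units; within the scatter). Compound 4 is estimated at 3500 nM, with an expected range of 1700 nM to 6500 nM.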

Compound 4, half-maximal inhibitory concentration: 13000 nM
Compound 4: the middle estimate sits 3.7-fold (0.57 log units) below what was measured; measured number outside the range, above it.
By their numbers in this assay, from the lowest: compound 3; then compounds 2, 1 and 4 (each within the scatter of the next, the first and the last beyond it).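

In this assay, the two halogens at this position next to the ring nitrogen do not behave alike: swapping chloro for fluoro gives a 5.4-fold higher number from compound 3 to compound 4 (0.73 log units; beyond the scatter). Fluoro also goes the opposite way to chloro when set against hydrogen, with a 2.5-fold higher number from compound 2 to compound 4 (0.41 log units; beyond the scatter), so putting a halogen here does not in itself lower the number. Nothing available explains this difference between chloro and fluoro.

Going by these compounds, whether bromo, methyl or methoxy at this position would follow chloro or fluoro remains open.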